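A few compounds are considered here, and "the series" means these few. Any claim that something is new, unique, unknown or untested is made for them only; others in the source may bear on it.

Measured in an ADME assay on HEp-2 cells (Homo sapiens) for cytotoxicity, read by trypan blue exclusion, with a stated time of 24 h; on this read-out higher numbers stand for lower toxicity in this test and lower numbers for higher toxicity in this test:
- compound 1 (`CCCCC/C(C)=N/N=C1\SCC(=O)N1Cc1ccc([N+](=O)[O-])cc1`): 35 ug/mL
- compound 2 (`CC(C)=N/N=C1\SCC(=O)N1CN1C(=O)c2ccccc2C1=O`): 22 ug/mL
- compound 3 (`C/C(CC(C)C)=N\N=C1/SCC(=O)N1Cc1cccc2ccccc12`): 95 ug/mL

Compound 1 sits in the middle of this small set. Its value lies within the usual scatter of repeated measurements from that of compound 2, so these two cannot be told apart in this assay. Compound 3 stands clearly higher than both, beyond that scatter, which makes it the least toxic of the three in this test.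

The next compound to be measured is compound 4 (`C/C(CC(C)C)=N\N=C1/SCC(=O)N1Cc1ccc([N+](=O)[O-])cc1`). It keeps the core of compound 1 and differs in one place: isopropyl in place of butyl on a saturated chain carbon bound to a carbon with a double bond to nitrogen. In words, this is isopropyl in place of butyl on a saturated chain carbon bound to a carbon with a double bond to nitrogen.

Going by the values given here, no two measured compounds differ in only one place, so the data offer no direct guide to the effect of such a swap. Both groups are carbon chains with no ring and no net charge, so no step beyond the scatter is expected in this assay, and no firm direction either. The expected step is a 1.1-fold higher number from compound 1 to compound 4 (0.06 log units; within the scatter). For compound 4 the estimated value is 40 ug/mL, with an expected range of 18 ug/mL to 90 ug/mL.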

Compound 4, half-maximal cytotoxic concentration: 32 ug/mL
Compound 4: middle estimate off by 1.3-fold (0.10 log units), on the high side, within the range that was stated.
By their numbers in this assay, from the lowest: compounds 2, 4 and 1 (each within the scatter of the next); then compound 3.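

Going by these compounds alone, compound 1 and compound 4 form the first pair here that differs in only one place, which gives a direct reading of this change. Isopropyl in place of butyl on a saturated chain carbon bound to a carbon with a double bond to nitrogen gives a 1.1-fold lower number from compound 1 to compound 4 (0.04 log units; within the scatter) in this assay, so the two compounds cannot be told apart in this test. Replacing butyl, with 4 carbons, by isopropyl, with 3 carbons, therefore leaves no readable mark on cytotoxicity for this one pair, and no measurement shown here offers an explanation for that result.

Both groups are carbon chains with no ring and no net charge, so the compounds shown leave open how this place would respond to a different kind of group, such as an amine, a carboxylic acid or a phenyl ring. They also leave open whether a much longer chain, such as decyl, would remain as close to compound 1, and whether the same swap would read alike if another part of the molecule were changed.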